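From One Methoxy to Three on the Pendant Ring

This account rests on a few compounds, and the source may have more. Where it says the series, first, only, none or still open, it means among the compounds named here.

Of the compounds shown here, three built on a shared core have been measured in a functional assay on UACC-62 cells (Homo sapiens) for inhibition; on this read-out lower numbers stand for stronger inhibition of growth and higher numbers for weaker inhibition of growth. Compound 1 `COc1cc(/C=C/C(=O)c2cccc(-n3cc(-c4ccc(Cl)cc4)[nH]c3=O)c2)cc(OC)c1OC` gives 8880 nM, compound 2 `COc1cc(/C=C/C(=O)c2cccc(-n3cc(-c4ccccc4)[nH]c3=O)c2)cc(OC)c1OC` gives 1520 nM, and compound 3 `COc1ccc(-c2cn(-c3cccc(C(=O)/C=C/c4cc(OC)c(OC)c(OC)c4)c3)c(=O)[nH]2)cc1` gives 2060 nM. Among these three numbers compound 3 sits close to compound 2, since a 1.4-fold higher number from compound 2 to compound 3 (0.13 log units; within the scatter), while its distance to compound 1 is real: a 4.3-fold lower number from compound 1 to compound 3 (0.63 log units; beyond the scatter). The other step, a 5.8-fold lower number from compound 1 to compound 2 (0.77 log units; beyond the scatter), points the same way.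

Compound 4 `COc1cc(/C=C/C(=O)c2cccc(-n3cc(-c4cc(OC)c(OC)c(OC)c4)[nH]c3=O)c2)cc(OC)c1OC` is the compound still to be measured. It differs from compound 3 by 3,4,5-trimethoxyphenyl in place of 4-methoxyphenyl on an aromatic carbon. The measured step that bears on this is the one already made on the same aromatic carbon, where methoxy replaced hydrogen: a 1.4-fold higher number from compound 2 to compound 3 (0.13 log units; within the scatter), a change that stayed inside the scatter. For the measured compounds named here, two further methoxy groups go onto that ring in compound 4, and nothing among the measured compounds shows whether these add or take away; the single methoxy step gives no direction. Going by the values given here, the expected step in this assay is therefore a 1.3-fold higher number from compound 3 to compound 4 (0.10 log units; within the scatter), with no change beyond the scatter expected, though the range is kept wide: only one related step exists. Compound 4 is thus estimated at 2600 nM, between 900 nM and 8000 nM.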

Compound 4, concentration for 50% growth inhibition: 1870 nM
Compound 4: middle estimate off by 1.4-fold (0.14 log units), on the high side, and the stated range covers the measured number.
By their numbers in this assay, from the lowest: compounds 2, 4 and 3 (each within the scatter of the next); then compound 1.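

In this assay the full set of three methoxy groups on the ring at this carbon makes little difference: the step stays inside the scatter (a 1.1-fold lower number from compound 3 to compound 4 (0.04 log units; within the scatter)), and so does the step that starts from plain phenyl (a 1.2-fold higher number from compound 2 to compound 4 (0.09 log units; within the scatter)). For the compounds shown here, on this read-out, therefore, phenyl, 4-methoxyphenyl and 3,4,5-trimethoxyphenyl on an aromatic carbon of the five-membered aromatic ring with 2 nitrogen cannot be told apart, so the count of methoxy groups shows no trend across compounds 2, 3 and 4, while compound 1 with its 4-chlorophenyl remains the one compound apart, now also against the trimethoxy group (a 4.7-fold lower number from compound 1 to compound 4 (0.68 log units; beyond the scatter)). Nothing available accounts for why the chloro compound stands apart from the other three.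

As far as these compounds go, whether that distance belongs to chloro itself or would recur with bromo or methyl on the same phenyl ring stays open. Also open, from the compounds shown here alone, is how this position would respond to an amine or a carboxylic acid on that ring, or to a longer chain in place of the ring.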